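A few compounds are considered here, and "the series" means these few. Any claim that something is new, unique, unknown or untested is made for them only; others in the source may bear on it.

Going by the values given here, in a functional assay on SGC-7901 cells (Homo sapiens) for inhibition, read by MTT assay, with a stated time of 24 h (on this read-out lower numbers stand for stronger inhibition and higher numbers for weaker inhibition), two compounds sharing one core have numbers so far. Compound 1 `CC1(C)[C@H]2CC[C@]1(C)N(Cc1cn(-c3ccccc3Cl)nn1)C(=O)C2`, which carries a 2-chlorophenyl group, gives 220 nM. Compound 2 `Cc1ccc(-n2cc(CN3C(=O)C[C@@H]4CC[C@@]3(C)C4(C)C)nn2)cc1`, which carries a 4-methylphenyl group, gives 390 nM, and these two numbers lie within the usual scatter of each other. Compound 3 `CC1(C)[C@H]2CC[C@]1(C)N(Cc1cn(-c3ccc(Cl)cc3)nn1)C(=O)C2` differs from compound 2 by one small swap, chloro in place of methyl on an aromatic carbon, para to a large group, which turns 4-methylphenyl into 4-chlorophenyl. Among the compounds with values here, only one measured step bears on this change, a 1.8-fold higher number from compound 1 to compound 2 (0.25 log units; within the scatter). That step stays within the scatter and involves the same 4-methylphenyl group, so no step beyond the scatter is expected in this assay. The expected step is a 1.3-fold lower number from compound 2 to compound 3 (0.13 log units; within the scatter). Compound 3 is estimated at 290 nM, with an expected range of 140 nM to 600 nM.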

Compound 3, half-maximal inhibitory concentration: 410 nM
Compound 3: middle estimate off by 1.4-fold (0.15 log units), on the low side, and the stated range covers the measured number.
By their numbers in this assay, from the lowest: compounds 1, 2 and 3 (each within the scatter of the next).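

The para position takes a chloro as readily as a methyl in this assay, since this swap stays within the scatter (a 1.1-fold higher number from compound 2 to compound 3 (0.02 log units; within the scatter)). Going by these compounds alone, the new compound also gives the first comparison of the same chloro group in two places on the phenyl ring, and 4-chlorophenyl in place of 2-chlorophenyl also stays within the scatter (a 1.9-fold higher number from compound 1 to compound 3 (0.27 log units; within the scatter)). So neither the identity of this small group nor the place of the chloro separates these compounds, and no measurement offered here explains that result. Methyl and chloro are both single-heavy-atom groups, so it remains open whether something larger or quite different on the phenyl ring, such as an amine, a carboxylic acid or a longer chain, would move the number beyond the scatter. As far as these compounds go, the effect of changing the shared core also remains open.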